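Notes on the pendant aryl group: compound 3 to compound 4

A few compounds are considered here, and "the series" means these few. Any claim that something is new, unique, unknown or untested is made for them only; others in the source may bear on it.

Measured so far:
Compound 1 `COc1ccc(CN2C(=O)C(=O)c3cc(-c4ccc(C(C)(C)C)cc4)ccc32)cc1`: in a functional assay on K562 cells (Homo sapiens) for antiproliferative activity, read by MTT assay, with a stated time of 48 h (on this read-out higher numbers stand for weaker inhibition and lower numbers for stronger inhibition), compound 1 gives 2250 nM.
Compound 2 `COc1ccc(CN2C(=O)C(=O)c3cc(-c4ccc(C#N)cc4)ccc32)cc1`: in this assay compound 2 gives 260 nM.
Compound 3 `COc1ccc(CN2C(=O)C(=O)c3cc(-c4ccc(C(F)(F)F)cc4)ccc32)cc1`: in this assay compound 3 gives 350 nM.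

Compound 3 stands second highest of the three numbers. Its nearest neighbour is compound 2, with a 1.3-fold higher number from compound 2 to compound 3 (0.13 log units; within the scatter), so the two cannot be separated. Its furthest neighbour is compound 1, with a 6.4-fold lower number from compound 1 to compound 3 (0.81 log units; beyond the scatter).

Compound 4 `COc1ccc(CN2C(=O)C(=O)c3cc(-c4ccc5ccccc5c4)ccc32)cc1` is the next member. Its change from compound 3 is naphthalen-2-yl in place of 4-(trifluoromethyl)phenyl on an aromatic carbon.

The measured steps all exchange one group on the pendant six-membered ring: an 8.7-fold lower number from compound 1 to compound 2 (0.94 log units; beyond the scatter) and a 6.4-fold lower number from compound 1 to compound 3 (0.81 log units; beyond the scatter) are the two steps of useful size, while a 1.3-fold higher number from compound 2 to compound 3 (0.13 log units; within the scatter) is flat. Among the measured compounds shown here, no measured step replaces the pendant ring itself by a two-ring aromatic system, so none bears directly on this change; they show only that the pendant group can move the number by a modest amount in either direction. The expectation for compound 4 is therefore wide and centred a little above compound 3, as a 2.0-fold higher number from compound 3 to compound 4 (0.30 log units; within the scatter).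

Compound 4 is estimated at 700 nM, with a range from 200 nM to 2500 nM.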

Compound 4, half-maximal inhibitory concentration: 340 nM
Estimate against measurement, compound 4: 2.1-fold (0.31 log units) above; measured number inside the range.
By their numbers in this assay, from the lowest: compounds 2, 4 and 3 (each within the scatter of the next); then compound 1.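

In this assay, a fused two-ring aromatic group on this aromatic carbon cannot be separated from the two best single-ring groups: a 1.0-fold lower number from compound 3 to compound 4 (0.01 log units; within the scatter), and a 1.3-fold higher number from compound 2 to compound 4 (0.12 log units; within the scatter). The earlier compounds shown here varied only the group on the pendant phenyl ring, whereas this result shows that the ring itself can be replaced by naphthalen-2-yl with no readable shift, so the position accepts more than one aromatic shape at this level of the read-out. Among the compounds shown here, the only step of size is still the one leaving 4-(tert-butyl)phenyl, a 6.6-fold lower number from compound 1 to compound 4 (0.82 log units; beyond the scatter), so that group alone stands apart among the four pendant groups, and nothing at hand accounts for this or for the level result.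

Open, going by these compounds, is whether the level seen for compound 2, compound 3 and compound 4 extends to a pyridine ring in place of the pendant phenyl, or to a carboxylic acid or an amine on that ring. Also open, on these data alone, is whether it holds when the rest of the molecule changes, since all four compounds keep the core of compound 1.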